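Cyclohexylmethyl to benzyl on the aromatic nitrogen

This account rests on a few compounds, and the source may have more. Where it says the series, first, only, none or still open, it means among the compounds named here.

Measured compounds:
compound 1 `Cc1cc(NC(=O)Cn2nnc(-c3ccccc3)n2)n(C2CCOCC2)n1`: 115%
compound 2 `Cc1cc(NC(=O)Cn2nnc(-c3ccccc3)n2)n(C2CCS(=O)(=O)CC2)n1`: > 25% (a limit of the assay)
compound 3 `Cc1cc(NC(=O)Cn2nnc(-c3ccccc3)n2)n(CC2CCCCC2)n1`: 77%

In an assay on HEK293 cells for activation of Kir3.1/Kir3.2 (Homo sapiens), read by thallium flux (a lower number here means a smaller maximal response, a higher number a larger maximal response), compound 1 gives 115%. Compound 2 reaches only a limit in this assay, > 25%, and no number. Compound 3 gives 77%, the lowest of the two numbers shown; its nearest neighbour is compound 1, with a number 38 percentage points lower from compound 1 to compound 3 (beyond the scatter). The steps a step that the limit leaves unreadable from compound 1 to compound 2 and a step that the limit leaves unreadable from compound 2 to compound 3 cannot be sized because of the limit of > 25% in this assay, at which 1 of the 3 values shown sits.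

Compound 4 `Cc1cc(NC(=O)Cn2nnc(-c3ccccc3)n2)n(Cc2ccccc2)n1` carries phenyl in place of cyclohexyl on a saturated chain carbon bound to an aromatic nitrogen. For the measured compounds named here, no measured step exchanges a saturated ring for an aromatic one at this position; the only readable step, a number 38 percentage points lower from compound 1 to compound 3 (beyond the scatter), changes oxan-4-yl to cyclohexylmethyl and so bears on it only loosely. The maximal response is therefore expected to stay near that of compound 3, with a step of no clear direction beyond the scatter.

Compound 4 is expected to give 78%, in the range 50% to 108%. The expected step is a number 1 percentage points higher from compound 3 to compound 4 (within the scatter), estimated to lie within the scatter.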

Compound 4, largest response reached (Emax), in percent of the reference or control that the assay uses: 74%
Compound 4: the middle estimate sits 4 percentage points above what was measured; low and high end bracket the measured number.
By their numbers in this assay, from the lowest: compounds 4 and 3 (each within the scatter of the next); then compound 1.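

In this assay, phenyl in place of cyclohexyl on a saturated chain carbon bound to an aromatic nitrogen gives a number 3 percentage points lower from compound 3 to compound 4 (within the scatter), so the saturated and the aromatic six-membered ring cannot be told apart at this place. The benzyl group also repeats what cyclohexylmethyl showed against oxan-4-yl, with a number 41 percentage points lower from compound 1 to compound 4 (beyond the scatter) set beside a number 38 percentage points lower from compound 1 to compound 3 (beyond the scatter), so this gap to compound 1 now holds for two different groups. The steps to compound 2 cannot be read, its value being a limit of the assay: the limit of > 25% in this assay, at which 1 of the 4 values shown sits.

Both groups differ from oxan-4-yl in the ring and in the saturated chain carbon, so the compounds shown do not separate these two changes, which oxan-4-ylmethyl would address. On these data alone, a longer chain such as 2-phenylethyl, or an amine or a carboxylic acid on the phenyl ring, also remains open.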